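Imidazole in Place of a Piperidine Tail: Expected Binding

The compounds below may be only part of what the source reports. "The series", "measured", "known", "first", "only" and "open" are said of these compounds alone.

compound 1 `Cn1c(=O)c2[nH]c(-c3ccc(OCCC4CCNCC4)cc3)nc2n(C)c1=O`: 1.33 nM
compound 2 `Cn1c(=O)c2[nH]c(Cc3ccc(OCCCN4CCC5(CC4)OCCO5)cc3)nc2n(C)c1=O`: > 30 nM

Among the compounds with values here, in an assay on CHO cells for displacement of a labelled ligand from adenosine receptor A1 (Homo sapiens), read by scintillation counting, with a stated time of 3 h (on this read-out lower numbers stand for stronger inhibition and higher numbers for weaker inhibition), compound 1 gives 1.33 nM, the only firm number among the two compounds measured. Compound 2 reaches only a limit of the assay, > 30 nM. Within the data shown here, that limit, (the limit of > 30 nM in this assay, at which 1 of the 2 values shown sits), is all that is known of compound 2, so no measured step links the two and nothing is known of what the tail change does.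

Compound 3 `Cn1c(=O)c2[nH]c(-c3ccc(OCCCn4ccnc4)cc3)nc2n(C)c1=O` differs from compound 1 by (1H-imidazol-1-yl)methyl in place of piperidin-4-yl on a saturated chain carbon, two bonds along the chain from an oxygen on an aromatic ring. Among the measured compounds shown here, no comparable step exists here. The expectation rests on compound 1 alone and on the change itself, and a modest weakening is expected, not far beyond the usual scatter. Compound 3 is expected to give about 5 nM, between 1.5 nM and 20 nM. The expected step of a 3.8-fold higher number from compound 1 to compound 3 (0.58 log units; beyond the scatter) therefore points toward weaker binding.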

Compound 3, inhibition constant: 0.89 nM
Compound 3: middle estimate off by 5.6-fold (0.75 log units), on the high side; the measured number lies below the stated range.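

In this assay, within the data shown here, the change reads a 1.5-fold lower number from compound 1 to compound 3 (0.17 log units; within the scatter) and gives the first measured step at this position. On a saturated chain carbon, two bonds along the chain from an oxygen on an aromatic ring, (1H-imidazol-1-yl)methyl can replace piperidin-4-yl with no change beyond the usual scatter, even though the non-aromatic ring and its hydrogen-bond donor are gone. No measurement shown gives a reason for this result.

Going by these compounds, whether a simple open-chain amine or a carboxylic acid at the end of this chain would also keep binding stays open. So does the effect of a longer chain carrying the imidazole.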